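Aryl swap on the nitrogen on an aromatic ring

This account rests on a few compounds, and the source may have more. Where it says the series, first, only, none or still open, it means among the compounds named here.

The three measured compounds share one core and differ only in the aryl group on a nitrogen on an aromatic ring. Compound 1 `COc1cc(NC(=O)Nc2cc(Nc3ccc(OC)c(C)c3)ncn2)cc(OC)c1` carries 4-methoxy-3-methylphenyl there; in a functional assay on NCI-H226 cells (Homo sapiens) for inhibition, read by MTT assay, with a stated time of 48 h, tested at 10 uM (on this read-out higher numbers stand for more inhibition at the one concentration tested (going by the name of the read-out) and lower numbers for less inhibition), compound 1 gives 39.7%. Compound 2 `CCc1cccc(Nc2cc(NC(=O)Nc3cc(OC)cc(OC)c3)ncn2)c1` carries 3-ethylphenyl, and in this assay compound 2 gives 36.7%. Compound 3 `COc1cc(NC(=O)Nc2cc(Nc3ccc(C)c(F)c3)ncn2)cc(OC)c1` carries 3-fluoro-4-methylphenyl, and in this assay compound 3 gives 39.7%. Compound 3 thus stands level with compound 1, the two together the highest of the three numbers, though the gap to compound 2 is within the scatter: the step of no change at the digits printed from compound 1 to compound 3 (within the scatter) and the step of a number 3 percentage points higher from compound 2 to compound 3 (within the scatter) both stay inside it, as does a number 3 percentage points lower from compound 1 to compound 2 (within the scatter). No aryl change at this nitrogen has so far moved the read-out beyond the scatter.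

Compound 4 `COc1cc(NC(=O)Nc2cc(Nc3cc(C)cc(F)c3)ncn2)cc(OC)c1` is not yet measured. It differs from compound 3 by 3-fluoro-5-methylphenyl in place of 3-fluoro-4-methylphenyl on a nitrogen on an aromatic ring, the same atoms joined differently. Going by the values given here, the steps that bear on it are the three aryl swaps at this nitrogen, each within the scatter, though none of them kept the same set of atoms. On that record the expected step of a number 1.7 percentage points lower from compound 3 to compound 4 (within the scatter) is none beyond the scatter. Compound 4 is therefore estimated at 38%, with a range from 26% to 50% in this assay.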

Compound 4, a percentage reported as inhibition, at one concentration (the size of the read-out at that concentration, not a potency): 35.3%
Estimate against measurement, compound 4: 2.7 percentage points above, and the stated range covers the measured number.
By their numbers in this assay, from the lowest: compounds 4, 2, 1 and 3 (each within the scatter of the next).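

Going by these compounds alone, compound 4 gives the first step at this nitrogen that keeps the same atoms and only rearranges them: in this assay the swap of 3-fluoro-4-methylphenyl for 3-fluoro-5-methylphenyl reads a number 4.4 percentage points lower from compound 3 to compound 4 (within the scatter) and so does not separate the two isomers. The two steps to the other aryl groups, a number 1.4 percentage points lower from compound 2 to compound 4 (within the scatter) and a number 4.4 percentage points lower from compound 1 to compound 4 (within the scatter), also stay inside the scatter, so all four aryl groups on this nitrogen remain indistinguishable on this read-out, whether the change alters the atoms or only their arrangement. Nothing measured here accounts for where these numbers fall.

Going by these compounds, whether a phenyl group carrying a morpholine, a carboxylic acid or a longer chain such as hexyl on this nitrogen would move the read-out beyond the scatter remains open. Also open, on these data alone, is whether these four compounds, which cannot be told apart at the one concentration tested, would separate across a full concentration series or in other cell lines.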